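The source may report more compounds than this note shows. Statements on the series, on what has been measured and on what is new or still open speak of the compounds shown alone.

Measured in a functional assay on B16-F10 cells (Mus musculus) for inhibition, read by MTT assay, with a stated time of 72 h; on this read-out higher numbers stand for weaker inhibition and lower numbers for stronger inhibition:
- compound 1 `COc1ccc(NC(=S)NC2CC(C)(C)Oc3ccc(Br)cc32)cc1`: "not determined" (no result reported)
- compound 2 `CC1(C)CC(NC(=S)Nc2ccc(C#N)cc2)c2cc(F)ccc2O1`: 5000 nM
- compound 3 `CC1(C)CC(NC(=S)Nc2ccc([N+](=O)[O-])cc2)c2cc(Br)ccc2O1`: 3000 nM

Compound 1 has no place on the scale of this assay, since its entry reads "not determined" (no result reported). Among the measured compounds shown here, the only numbers come from compound 2 at 5000 nM and compound 3 at 3000 nM, and these two lie within the usual scatter of each other.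

The next compound to be tested is compound 4 `CC1(C)CC(NC(=S)Nc2cccc(Cl)c2)c2cc(Br)ccc2O1`, which shares the core of compound 1. The structural change is 3-chlorophenyl in place of 4-methoxyphenyl on an amide-type nitrogen. In words, 3-chlorophenyl stands in place of 4-methoxyphenyl on an amide-type nitrogen.

For the measured compounds named here, with no number for compound 1, no step can be sized from it in this assay, so neither a size nor a direction is expected for this change. The expectation rests instead on compound 3 at 3000 nM and compound 2 at 5000 nM, and no departure beyond the scatter from these values is anticipated. The expected value for compound 4 is 4000 nM, with an estimated range of 1500 nM to 12000 nM.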

Compound 4, half-maximal inhibitory concentration: 7000 nM
Beside the measured number, compound 4's estimate is 1.8-fold (0.24 log units) below it; measured number inside the range.
By their numbers in this assay, from the lowest: compounds 3, 2 and 4 (each within the scatter of the next, the first and the last beyond it).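

In this assay, among the compounds shown here, compound 1 stands as "not determined" (no result reported) and so no step from it to compound 4 can be read. The compounds shown leave open whether 3-chlorophenyl in place of 4-methoxyphenyl changes inhibition on the shared core. No further data bear on this result.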